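Carboxy Replacing Methyl on the Side Chain Next

The source may report more compounds than this note shows. Statements on the series, on what has been measured and on what is new or still open speak of the compounds shown alone.

Two compounds share one core and differ only in a short chain on an aromatic nitrogen. In a functional assay on a cell-free system (plasma, Oryctolagus cuniculus) for inhibition of platelet-activating factor acetylhydrolase (Homo sapiens), tested at 100 nM (on this read-out higher numbers stand for more inhibition at the one concentration tested (going by the name of the read-out) and lower numbers for less inhibition), compound 1 `CCCCCCCCN(C)C(=O)Cn1cc(Cc2cnc(=O)n(C)c2)c(=O)nc1SCc1ccc(F)cc1` gives 19%. For the measured compounds named here, compound 2 `CCCCCCCCN(C)C(=O)Cn1cc(Cc2cnc(=O)n(CC)c2)c(=O)nc1SCc1ccc(F)cc1`, carrying methyl in place of hydrogen on a saturated chain carbon bound to an aromatic nitrogen, gives 5% in this assay, the lowest of the two numbers; the only measured step, a number 14 percentage points lower from compound 1 to compound 2 (beyond the scatter), lies beyond the scatter. Compound 3 `CCCCCCCCN(C)C(=O)Cn1cc(Cc2cnc(=O)n(CC(=O)O)c2)c(=O)nc1SCc1ccc(F)cc1` carries the change (carboxy in place of methyl on a saturated chain carbon bound to an aromatic nitrogen). Going by the values given here, no measured step involves a carboxy group, so the single step from compound 1 to compound 2 shows only that this chain position can move the read-out. With compound 2 already near the bottom of the range, compound 3 is expected to show a step of a number 3 percentage points higher from compound 2 to compound 3 (within the scatter), staying within the scatter. The estimate for compound 3 in this assay is 8%, ranging from -5% to 25%.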

Compound 3, a percentage reported as inhibition, at one concentration (the size of the read-out at that concentration, not a potency): 27%
Beside the measured number, compound 3's estimate is 19 percentage points below it; the whole stated range lies below it.
By their numbers in this assay, from the lowest: compound 2; then compounds 1 and 3 (each within the scatter of the next).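

In this assay, carboxy in place of methyl on a saturated chain carbon bound to an aromatic nitrogen reverses the earlier loss (a change reading a number 22 percentage points higher from compound 2 to compound 3 (beyond the scatter)), so a larger group at this place does not always leave the read-out low. Compared with the methyl of compound 1, the carboxymethyl chain gives a step that reads a number 8 percentage points higher from compound 1 to compound 3 (within the scatter), so these two chains cannot be told apart here. Nothing available explains why ethyl and carboxymethyl differ in this way.

As far as these compounds go, whether a hydroxyethyl chain, a primary amide or an amine at this place would read like carboxymethyl or like ethyl remains open. From the compounds shown here alone, each number also comes from a single concentration, so how the three compounds compare in potency remains open too.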